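This account rests on a few compounds, and the source may have more. Where it says the series, first, only, none or still open, it means among the compounds named here.

Three compounds share one core. Compound 1 `CC(C)c1c(C(=O)N(C)Cc2ccccc2)nn(-c2ccc(F)cc2)c1OC[C@@H](O)C[C@@H](O)CC(=O)O` gives 5.2 nM in an assay on microsomes from liver for inhibition of 3-hydroxy-3-methylglutaryl-coenzyme A reductase (Rattus norvegicus); a lower number here means a stronger inhibitor, a higher number a weaker inhibitor. Compound 2 `COc1ccccc1CNC(=O)c1nn(-c2ccc(F)cc2)c(OC[C@@H](O)C[C@@H](O)CC(=O)O)c1C(C)C` gives 22 nM in this assay, and compound 3 `CC(C)c1c(C(=O)N(C)Cc2cccc(F)c2)nn(-c2ccc(F)cc2)c1OC[C@@H](O)C[C@@H](O)CC(=O)O` gives 14 nM in this assay. Compound 3 holds the second highest number of the three: the step of a 1.6-fold lower number from compound 2 to compound 3 (0.20 log units; within the scatter) lies within the scatter, while the step of a 2.7-fold higher number from compound 1 to compound 3 (0.43 log units; beyond the scatter) lies beyond it.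

Compound 4 `COc1cccc(CN(C)C(=O)c2nn(-c3ccc(F)cc3)c(OC[C@@H](O)C[C@@H](O)CC(=O)O)c2C(C)C)c1` differs from compound 3 in one place: methoxy in place of fluoro on an aromatic carbon. Going by the values given here, no measured pair exchanges these two groups directly. The step of a 2.7-fold higher number from compound 1 to compound 3 (0.43 log units; beyond the scatter) shows what the entering fluoro did, and the step of a 4.2-fold higher number from compound 1 to compound 2 (0.63 log units; beyond the scatter) shows a methoxy entering on the benzyl together with loss of the methyl on the amide nitrogen; the step of a 1.6-fold lower number from compound 2 to compound 3 (0.20 log units; within the scatter), which trades one of these arrangements for the other, stays within the scatter. Taken together these point to at most a modest movement in this assay, with no clear direction. Compound 4 is therefore expected to give about 16 nM in this assay, within a range from 7 nM to 40 nM. The expected step of a 1.1-fold higher number from compound 3 to compound 4 (0.06 log units; within the scatter) would stay within the scatter.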

Compound 4, half-maximal inhibitory concentration: 21 nM
For compound 4 the middle estimate is 1.3-fold (0.12 log units) below the measured one, and the stated range covers the measured number.
By their numbers in this assay, from the lowest: compound 1; then compounds 3, 4 and 2 (each within the scatter of the next).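

In this assay, the exchange of fluoro for methoxy on the aromatic carbon gives a 1.5-fold higher number from compound 3 to compound 4 (0.18 log units; within the scatter) and so does not tell the two groups apart. Methoxy in place of hydrogen at this same position gives a 4.0-fold higher number from compound 1 to compound 4 (0.61 log units; beyond the scatter) and thus, like fluoro, leaves the number beyond the scatter of that of compound 1, so the shift at this position is not confined to one group. The step of a 1.0-fold lower number from compound 2 to compound 4 (0.02 log units; within the scatter) shows that the 3-methoxybenzyl(methyl)amino and 2-methoxybenzylamino arrangements cannot be separated in this assay either.

No measurement here gives a reason for any of these steps. Going by these compounds, whether a chlorine, a hydroxyl or an amine on this aromatic carbon would bring the number back to that of compound 1 or leave it with compound 3 and compound 4 stays open.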